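The compounds below may be only part of what the source reports. "The series", "measured", "known", "first", "only" and "open" are said of these compounds alone.

In an ADME assay on Karpas-1106P cells (Homo sapiens) for cytotoxicity (a higher number here means that more compound is needed for the effect, a lower number that less compound is needed), compound 1 `Cc1ccc(S(=O)(=O)N[C@@H](CC(=O)NC(C)(C)C)C(=O)NCCNC(=O)NCc2ccccc2)cc1` gives > 11100 nM, a limit of the assay rather than a number. Compound 2 `Cc1ccc(S(=O)(=O)N[C@@H](CC(=O)NC(C)(C)C)C(=O)NCCNC(=O)c2ccc(F)cc2)cc1` in this assay gives > 11100 nM, again a limit. The step that the two limits leave unreadable from compound 1 to compound 2 is thus unreadable, since both values sit at the limit of > 11100 nM in this assay, at which 2 of the 2 values shown sit. Compound 3 `COc1cccc(C(=O)NCCNC(=O)[C@H](CC(=O)NC(C)(C)C)NS(=O)(=O)c2ccc(C)cc2)c1` carries 3-methoxyphenyl in place of 4-fluorophenyl on a carbonyl carbon. For the measured compounds named here, no measured step bears on this change; the single comparison available is the unreadable one, so no step beyond the scatter is expected in either direction. For compound 3 the expected step is a step that the limit leaves unreadable from compound 2 to compound 3. Compound 3 is expected at 15000 nM, within 8000 nM to 30000 nM, most likely reported once more as a limit.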

Compound 3, half-maximal effective concentration: > 11100 nM
Compound 3: only a limit was reported (the forecaster's own chance of this, stated with the estimate: 80%); the middle value does not contradict the limit.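

Compound 1, compound 2 and compound 3 allow no readable step in this assay, since each value is a limit of the assay: the limit of > 11100 nM in this assay, at which 3 of the 3 values shown sit. The compounds shown leave open whether any group on this carbonyl carbon changes the half-maximal effective concentration.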